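A Benzyl Ester Variant in a Vitamin D Receptor Series

This account rests on a few compounds, and the source may have more. Where it says the series, first, only, none or still open, it means among the compounds named here.

Three measured compounds share one core and differ only in the group attached to the carbonyl. Compound 1 `C#CCNC(=O)c1ccc(C(CC)(CC)c2ccc(OCC(O)C(C)(C)C)c(C)c2)n1CC` carries a propargyl amide, and in an assay on HL-60 cells for agonist activity at vitamin D3 receptor (Homo sapiens), read by microscopy, with a stated time of 96 h (a lower number here means that less compound is needed, a higher number that more compound is needed for the effect), compound 1 gives 240 nM. Compound 2 `CCn1c(C(=O)Nc2cccc(C(F)(F)F)c2)ccc1C(CC)(CC)c1ccc(OCC(O)C(C)(C)C)c(C)c1` carries a 3-(trifluoromethyl)phenyl amide; in this assay compound 2 reaches only the limit > 50000 nM (the limit of > 50000 nM in this assay, at which 1 of the 3 values shown sits). Compound 3 `CCn1c(C(=O)Oc2ccc(CCO)cc2)ccc1C(CC)(CC)c1ccc(OCC(O)C(C)(C)C)c(C)c1` is a phenyl ester, and in this assay compound 3 gives 5100 nM, the highest of the two plain numbers, with compound 1 nearest. The steps of an at least 200-fold higher number from compound 1 to compound 2 (2.31 log units; beyond the scatter) and a 21-fold higher number from compound 1 to compound 3 (1.33 log units; beyond the scatter) are both large, and the step of an at least 9.8-fold lower number from compound 2 to compound 3 (0.99 log units; beyond the scatter) is at least modest, so the carbonyl substituent moves this read-out over a wide span.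

Compound 4 `CCn1c(C(=O)OCc2ccc(F)cc2)ccc1C(CC)(CC)c1ccc(OCC(O)C(C)(C)C)c(C)c1` has not yet been measured. It differs from compound 3 by 4-fluorobenzyl in place of 4-(2-hydroxyethyl)phenyl on an oxygen next to a carbonyl group. The two steps onto the ester oxygen bear on this change, but neither of them introduces a benzyl group, and the donor and acceptor of the hydroxyethyl chain leave. The account therefore expects for compound 4 a step of a 1.7-fold lower number from compound 3 to compound 4 (0.23 log units; within the scatter) in this assay, a modest lowering at most. The estimate for compound 4 is 3000 nM, within a range from 600 nM to 15000 nM.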

Compound 4, half-maximal effective concentration: > 50000 nM
Compound 4 was reported as a limit; the forecaster's own chance of this, stated with the estimate: 10%; at least 16-fold (1.22 log units) between middle value and limit.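

Compound 4 is reported in this assay only as a limit, > 50000 nM, and compound 2 also sits at that limit: the limit of > 50000 nM in this assay, at which 2 of the 4 values shown sit.

Putting 4-fluorobenzyl in place of 4-(2-hydroxyethyl)phenyl on an oxygen next to a carbonyl group gives an at least 9.8-fold higher number from compound 3 to compound 4 (0.99 log units; beyond the scatter), so the ester link alone does not secure a plain number in this series, and a change within the ester group can lose the read-out as fully as the 3-(trifluoromethyl)phenyl amide of compound 2 does. Measured against the propargyl amide, the change gives an at least 200-fold higher number from compound 1 to compound 4 (2.31 log units; beyond the scatter), which leaves compound 1 with the lowest number of the four, while the step between compound 2 and compound 4 cannot be read, as both are limits.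

On these data alone, the change removes the hydroxyethyl chain with its hydrogen-bond donor and also brings in fluorine and a benzyl link, so whether a 4-(2-hydroxyethyl)benzyl ester would keep a plain number stays open. As far as these compounds go, how a carboxylic acid on the carbonyl carbon or an amide with a longer chain than propargyl would read also remains open.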